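The compounds below may be only part of what the source reports. "The series", "measured", "known", "first", "only" and "open" are said of these compounds alone.

Among the compounds with values here, in a functional assay on HeLa cells (Homo sapiens) for inhibition, read by CCK-8 assay, with a stated time of 48 h (on this read-out lower numbers stand for stronger inhibition and higher numbers for weaker inhibition), compound 2 `COc1cc(-c2ccnc3cc(-c4ccc(C)c(C)c4)nn23)cc(OC)c1OC` gives 241 nM, the second highest of the three numbers measured so far. In this assay compound 1 `COc1cc(-c2ccnc3cc(-c4c[nH]c5ccccc45)nn23)cc(OC)c1OC` gives 195 nM, and compound 3 `COc1cc(-c2ccnc3cc(-c4cn(C)c5ccccc45)nn23)cc(OC)c1OC` gives 399 nM. Two of the measured steps exchange the group on the same aromatic carbon that is changed here: the step of a 1.2-fold higher number from compound 1 to compound 2 (0.09 log units; within the scatter) and the step of a 1.7-fold higher number from compound 2 to compound 3 (0.22 log units; within the scatter), and neither moves the number beyond the scatter. The remaining step, a 2.0-fold higher number from compound 1 to compound 3 (0.31 log units; beyond the scatter), concerns a methyl on an aromatic nitrogen and does not bear on the present change.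

Compound 4 `COc1cc(-c2ccnc3cc(-c4ccc(C(C)(C)C)cc4)nn23)cc(OC)c1OC` differs from compound 2 by 4-(tert-butyl)phenyl in place of 3,4-dimethylphenyl on an aromatic carbon. Because a 1.2-fold higher number from compound 1 to compound 2 (0.09 log units; within the scatter) and a 1.7-fold higher number from compound 2 to compound 3 (0.22 log units; within the scatter) both stayed within the scatter, compound 4 is expected to stay close to compound 2, with an expected step of a 1.2-fold higher number from compound 2 to compound 4 (0.10 log units; within the scatter) in this assay. Compound 4 is therefore estimated at 300 nM in this assay, with a range from 120 nM to 750 nM.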

Compound 4, half-maximal inhibitory concentration: > 10000 nM
Compound 4: no number, only a limit (the forecaster's own chance of this, stated with the estimate: 5%); middle value at least 33-fold (1.52 log units) from the limit.
By their numbers in this assay, from the lowest: compounds 1, 2 and 3 (each within the scatter of the next, the first and the last beyond it). At a limit, above all of these: compound 4.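

In this assay, compound 4 gives no number, only a limit: (the limit of > 10000 nM in this assay, at which 1 of the 4 values shown sits). The exchanges among compounds 1, 2 and 3 on this aromatic carbon of the five-membered ring gave no sign of it, but this position does not accept every carbon-only aromatic group alike: the step is an at least 41-fold higher number from compound 2 to compound 4 (1.61 log units; beyond the scatter) for 4-(tert-butyl)phenyl in place of 3,4-dimethylphenyl. The same holds against both indole-bearing compounds, with an at least 25-fold higher number from compound 3 to compound 4 (1.39 log units; beyond the scatter) and an at least 51-fold higher number from compound 1 to compound 4 (1.70 log units; beyond the scatter) as the steps.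

The true size of these steps cannot be read beyond what the limit allows. The compounds shown leave open whether a phenyl ring carrying a methyl, a methoxy group or an amine in place of tert-butyl would stay with compounds 1, 2 and 3 or go the way of compound 4.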